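The source may hold more compounds than are shown below. What is called first, only, known or untested is meant among the compounds shown, and "the series" means these compounds.

In a functional assay on A2780 cells (Homo sapiens) for cytotoxicity, read by MTT assay, with a stated time of 24 h (on this read-out lower numbers stand for stronger inhibition and higher numbers for weaker inhibition), compound 1 `CCCCC[C@H](CCC[C@@H]1CC=CC(=O)O1)OC` gives 14400 nM, compound 3 `CCCCC[C@H](CCC[C@H]1CC=CC(=O)O1)OC` gives 17100 nM, and compound 2 `CCCCC[C@@H](C[C@H](O)C[C@H]1CC=CC(=O)O1)OC` gives 53700 nM. Compound 3 therefore sits level with compound 1, while the number for compound 2 lies above both.

Compound 4 `CCCCC[C@@H](CCC[C@H]1CC=CC(=O)O1)OC` is related to compound 3 by a single change: the two compounds have the same atoms and bonds and differ only in configuration as drawn: 1 of 2 stereo elements differ; a stereocentre at a saturated chain carbon is drawn R in compound 3 and S in compound 4.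

Within the data shown here, one measured step bears on this, and only indirectly: a 1.2-fold higher number from compound 1 to compound 3 (0.07 log units; within the scatter). That step also changes one stereocentre only, but at a saturated ring carbon rather than a saturated chain carbon. Among the measured compounds shown here, no measured pair changes the chain centre itself, so the range has to stay wide. For the measured compounds named here, with the only configurational step lying within the scatter, no step beyond the scatter is expected in this assay, and no direction is favoured. The expected outcome is a 1.1-fold lower number from compound 3 to compound 4 (0.03 log units; within the scatter). For compound 4 the estimated value is 16000 nM, with an expected range of 8000 nM to 33000 nM.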

Compound 4, half-maximal inhibitory concentration: 20600 nM
Compound 4: middle estimate off by 1.3-fold (0.11 log units), on the low side, within the range that was stated.
By their numbers in this assay, from the lowest: compounds 1, 3 and 4 (each within the scatter of the next); then compound 2.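

With the chain centre now inverted on its own (a 1.2-fold higher number from compound 3 to compound 4 (0.08 log units; within the scatter)), both stereocentres have a single-centre step in this assay, and neither step goes beyond the scatter. Inverting both centres together, which gives the mirror image, also stays within the scatter (a 1.4-fold higher number from compound 1 to compound 4 (0.16 log units; within the scatter)), so among compounds 1, 3 and 4 no configuration stands apart. Among these compounds, the one step beyond the scatter is a change of group rather than of configuration: hydrogen in place of hydroxy on a saturated chain carbon bound to two saturated chain carbons (a 2.6-fold lower number from compound 2 to compound 4 (0.42 log units; beyond the scatter)).

As far as these compounds go, whether that step depends on the configuration of the hydroxy-bearing carbon remains open. So does what an amine or a carboxylic acid on that carbon would give, or a longer chain in the series.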